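The compounds below may be only part of what the source reports. "The series", "measured", "known", "first", "only" and "open" are said of these compounds alone.

In a functional assay on HT-29 cells (Homo sapiens) for inhibition, read by MTT assay, with a stated time of 48 h (on this read-out higher numbers stand for weaker inhibition and lower numbers for stronger inhibition), compound 1 `COc1cc(-c2cc(-c3ccccc3)nc(-c3ccccc3)n2)cc(OC)c1OC` gives 7930 nM and compound 2 `COc1cc(-c2cc(-c3ccc(O)cc3)nc(-c3ccccc3)n2)cc(OC)c1OC` gives 11300 nM, so these two values lie within the usual scatter of each other. Compound 3 `COc1cc(-c2cc(-c3cccc4ccccc34)nc(-c3ccccc3)n2)cc(OC)c1OC` has naphthalen-1-yl in place of 4-hydroxyphenyl on an aromatic carbon. For the measured compounds named here, one measured step bears on this, a 1.4-fold higher number from compound 1 to compound 2 (0.15 log units; within the scatter), where hydroxy replaced hydrogen on the ring that now leaves. Going by the values given here, that step is small, and naphthalen-1-yl itself has no measured precedent here. In this assay the expected result is therefore a 1.4-fold lower number from compound 2 to compound 3 (0.15 log units; within the scatter), with no step beyond the scatter. Compound 3 is estimated at 8000 nM, with an expected range of 3000 nM to 20000 nM.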

Compound 3, half-maximal inhibitory concentration: 4730 nM
Estimate against measurement, compound 3: 1.7-fold (0.23 log units) above, within the range that was stated.
By their numbers in this assay, from the lowest: compounds 3, 1 and 2 (each within the scatter of the next, the first and the last beyond it).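

Naphthalen-1-yl in place of 4-hydroxyphenyl gives a 2.4-fold lower number from compound 2 to compound 3 (0.38 log units; beyond the scatter) and is the first step at this position to pass beyond the scatter, though only modestly. Against the plain phenyl of compound 1, the same two-ring group gives a 1.7-fold lower number from compound 1 to compound 3 (0.22 log units; within the scatter) and stays within the scatter, so the second ring shows no clear gain over a single one. No available evidence explains either step. The compounds shown leave open how an amine, a methoxy group or a longer chain on the ring at this position would read out.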